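A new group on the nitrogen of compound 1

This account rests on a few compounds, and the source may have more. Where it says the series, first, only, none or still open, it means among the compounds named here.

Compound 1 `C/C=C/C(=O)Nc1cccc(Oc2nc(Nc3ccn(C)n3)nc3c2CSCC3)c1` offers no exact starting number: in a functional assay on A549 cells (Homo sapiens) for antiproliferative activity, read by MTT assay, with a stated time of 72 h (a higher number here means a weaker inhibitor, a lower number a stronger inhibitor), compound 1 gives > 50000 nM, which is a limit of the assay. Compound 3 `C=C(F)C(=O)Nc1cccc(Oc2nc(Nc3ccn(C)n3)nc3c2CSCC3)c1` gives > 50000 nM, also a limit. Only compound 2 `CC(C)/C=C/C(=O)Nc1cccc(Oc2nc(Nc3ccn(C)n3)nc3c2CSCC3)c1` has a true number, at 33500 nM.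

Compound 4 `C/C=C/C(=O)Nc1cccc(Oc2nc(Nc3ccc(OC)nc3)nc3c2CSCC3)c1` has 6-methoxypyridin-3-yl in place of 1-methyl-1H-pyrazol-3-yl on a nitrogen on an aromatic ring. The measured steps all change the group on the carbonyl carbon instead. One is an at least 1.4-fold lower number from compound 1 to compound 2 (0.17 log units; that floor lies within the scatter), and another is an at least 1.4-fold higher number from compound 2 to compound 3 (0.17 log units; that floor lies within the scatter). The step that the two limits leave unreadable from compound 1 to compound 3 cannot be sized. None of them measures the new change, so they give no firm size for it.

Within the data shown here, with compound 2 at 33500 nM as the only number, a modest move towards a lower number is the most that can be expected. The expected change is an at least 2.0-fold lower number from compound 1 to compound 4 (0.30 log units; that floor lies within the scatter). For compound 4 the estimated value is 25000 nM, with an expected range of 6000 nM to 60000 nM.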

Compound 4, half-maximal inhibitory concentration: 8040 nM
Estimate against measurement, compound 4: 3.1-fold (0.49 log units) above; the range from low to high includes it.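

Replacing the group on this nitrogen gives the first step in the series that is shown to lie beyond the scatter: in this assay there is an at least 6.2-fold lower number from compound 1 to compound 4 (0.79 log units; beyond the scatter). The earlier steps all changed the group on the carbonyl carbon, and none could be shown to exceed the scatter, so this nitrogen position is the first place where a single change has a clearly readable effect. The step is only a floor, and its full size stays unknown because compound 1 stands at a limit of the assay: the limit of > 50000 nM in this assay, at which 2 of the 4 values shown sit.

The swap changes the ring size, the hetero atoms and the attached methoxy group all at once, so the compounds shown cannot separate these parts. From the compounds shown here alone, a plain phenyl ring or a 6-aminopyridin-3-yl group on this nitrogen would be needed to test them, and the effect of the same swap alongside the other carbonyl groups remains open.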